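The source may hold more compounds than are shown below. What is called first, only, known or untested is meant among the compounds shown, and "the series" means these compounds.

Measured so far:
compound 1 `COc1ccc(C(=O)NNC(=S)Nc2csc(-c3ccccc3)c2)cc1OC` — 20000 nM
compound 2 `COc1ccc(C(=O)NNC(=S)Nc2csc(-c3ccc(C)cc3)c2)cc1OC` — 36000 nM
compound 3 `Oc1ccc(-c2nnc(Nc3csc(-c4ccccc4)c3)s2)cc1` — 15000 nM

All three were tested in a functional assay on A549 cells (Homo sapiens) for inhibition, read by colorimetric assay and MTT assay, with a stated time of 72 h; on this read-out higher numbers stand for weaker inhibition and lower numbers for stronger inhibition. Compound 1 gives 20000 nM in this assay. Compound 2 carries methyl in place of hydrogen on an aromatic carbon relative to compound 1, and the step is a 1.8-fold higher number from compound 1 to compound 2 (0.26 log units; within the scatter). Compound 3 gives 15000 nM; how its core differs from that of compound 1 is not broken down here, and its value stands within the scatter of compound 1 but beyond the scatter of compound 2.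

Compound 4 `Cc1ccc(-c2cc(Nc3nnc(-c4ccc(O)cc4)s3)cs2)cc1` has not been measured. It differs from compound 3 by methyl in place of hydrogen on an aromatic carbon, the same change already made from compound 1 to compound 2. Since that earlier step was a 1.8-fold higher number from compound 1 to compound 2 (0.26 log units; within the scatter), a step of about the same size and direction is expected from compound 3 to compound 4, namely a 1.8-fold higher number from compound 3 to compound 4 (0.26 log units; within the scatter). On this basis compound 4 is estimated at 27000 nM in this assay, with a likely range from 12000 nM to 60000 nM. The reading for compound 4 is awaited.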

Compound 4, half-maximal inhibitory concentration: 6000 nM
The estimate for compound 4 lay 4.5-fold (0.65 log units) above the measured number; the whole stated range lies above it.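

In this assay, methyl in place of hydrogen on the six-membered aromatic ring, para to a large group, gives a 2.5-fold lower number from compound 3 to compound 4 (0.40 log units; beyond the scatter), a modest gain on the core of compound 3. The same change therefore cannot be carried from one core to the other in this series as a fixed increment, since the two steps differ in direction and the gap between them exceeds what scatter alone would give: the same change on two cores in this assay, a 1.8-fold higher number (0.26 log units; within the scatter) from compound 1 to compound 2 and a 2.5-fold lower number (0.40 log units; beyond the scatter) from compound 3 to compound 4, 4.5-fold (0.65 log units) apart, beyond the scatter of two such steps. This rests on just two pairs and shows that the outcome of this change depends on the core, but it does not show which part of the core is responsible, nor how the change would behave on any further core.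

The compounds shown leave open how an amine, a carboxylic acid or a longer chain such as ethyl would behave at the same place on either core. They also leave open whether a third core would follow compound 3 and compound 4 or compound 1 and compound 2.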